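The compounds below may be only part of what the source reports. "The series", "measured", "known", "first", "only" and "open" are said of these compounds alone.

Of the compounds shown here, two of one series have been measured in an assay on isolated protein for inhibition of Rho-associated protein kinase 1 (Homo sapiens), read by scintillation counting, radiometric assay and 33P incorporation, with a stated time of 40 min, in the presence of a further agent that is not named here; on this read-out higher numbers stand for weaker inhibition and lower numbers for stronger inhibition. Compound 1, with the structure `Cc1coc2cc(OCC(=O)Nc3cccc(NC(=O)c4ccc(N(C)C)cc4)c3)ccc2c1=O`, gives only a limit in this assay, > 10000 nM, and so it stands at the limit of > 10000 nM in this assay, at which 1 of the 2 values shown sits. Compound 2, with the structure `CCCc1ccc(C(=O)Nc2cccc(NC(=O)COc3ccc4c(=O)ccoc4c3)c2)cc1`, gives 143 nM in this assay. Among the compounds with values here, this is the only number among the values shown, so compound 2 cannot be placed against a second number. Compound 3, with the structure `Cc1nc(C(=O)Nc2cccc(NC(=O)COc3ccc4c(=O)ccoc4c3)c2)cs1`, has not yet been measured. It differs from compound 2 in one place: 2-methyl-1,3-thiazol-4-yl in place of 4-propylphenyl on a carbonyl carbon. Within the data shown here, no measured step between two compounds tells how such a change plays out in this assay, so the expectation for compound 3 rests on compound 2 alone. The step expected from compound 2 to compound 3 is a 2.8-fold higher number from compound 2 to compound 3 (0.45 log units; beyond the scatter), a moderate weakening that may reach beyond the usual scatter. Compound 3 is estimated at 400 nM in this assay, with an expected range from 120 nM to 1500 nM.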

Compound 3, half-maximal inhibitory concentration: 473 nM
Compound 3: middle estimate off by 1.2-fold (0.07 log units), on the low side, within the range that was stated.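

Swapping the group on this carbonyl carbon in this assay gives the first step that can be read at this position (a 3.3-fold higher number from compound 2 to compound 3 (0.52 log units; beyond the scatter)). The 4-propylphenyl group is therefore not required for a measurable value, since 2-methyl-1,3-thiazol-4-yl, a five-membered aromatic ring with fewer heavy atoms, keeps inhibition in a measurable range while giving a modestly higher number. The change removes a carbon-only six-membered ring and its propyl chain and brings in two hydrogen-bond acceptors, but no measurement shown explains the step.

Which part of the change matters stays open, and an unsubstituted phenyl group, a 1,3-thiazol-4-yl group without the methyl, or a 1,3-thiazol-4-yl group carrying a longer chain such as propyl could help to separate the effect of the ring from that of its substituent. Within the data shown here, compound 1 gives only a limit of the assay (> 10000 nM) and differs from compound 2 in more than one place, so it offers no step to read at this position.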